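The compounds below may be only part of what the source reports. "The series", "measured", "known", "first", "only" and "open" are said of these compounds alone.

Values in a functional assay on SK-OV-3 cells (Homo sapiens) for antiproliferative activity, read by sulforhodamine B assay, with a stated time of 72 h; a lower number here means a stronger inhibitor, a higher number a weaker inhibitor:
- compound 1 `O=S(=O)(Nc1ncccn1)c1ccc(Nc2nncc3ccccc23)cc1`: 0.8 nM
- compound 2 `O=S(=O)(Nc1nccs1)c1ccc(Nc2nncc3ccccc23)cc1`: 7.7 nM
- compound 3 `Fc1ccc(Nc2nncc3ccccc23)cc1`: 0.06 nM

Compound 3 holds the lowest number of the three, and the other two compounds both sit well above it. Compound 4 `N#Cc1ccc(Nc2nncc3ccccc23)cc1` differs from it by cyano in place of fluoro on an aromatic carbon, with cyano in place of fluoro on an aromatic carbon, para to a large group. For the measured compounds named here, no measured step covers this place. The only one, a 9.6-fold higher number from compound 1 to compound 2 (0.98 log units; beyond the scatter), lies on a sulfonamide nitrogen and serves as a loose guide to size alone. With compound 3 at 0.06 nM, the bottom of the series, a move to a higher number of similar size is expected. The expected step is a 6.7-fold higher number from compound 3 to compound 4 (0.82 log units; beyond the scatter). For compound 4 the estimated value is 0.4 nM, with an expected range of 0.06 nM to 3 nM.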

Compound 4, half-maximal inhibitory concentration: 0.02 nM
For compound 4 the middle estimate is 20-fold (1.30 log units) above the measured one; the whole stated range lies above it.
By their numbers in this assay, from the lowest: compound 4; then compound 3; then compound 1; then compound 2.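

For the compounds shown here, this is the first measured step at the aromatic carbon para to a large group; the earlier step lay on a sulfonamide nitrogen. In this assay, the step is a 3.0-fold lower number from compound 3 to compound 4 (0.48 log units; beyond the scatter), so this position accepts cyano in place of fluoro with a lower number, even starting from an already low value. No measurement shown explains this step.

As far as these compounds go, whether an amine, a carboxylic acid or a longer chain at this position would keep numbers this low remains open, as does whether the same exchange would lower the number in other compounds.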